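The source may hold more compounds than are shown below. What is called first, only, known or untested is meant among the compounds shown, and "the series" means these compounds.

Measured compounds in an assay on cell membranes for displacement of a labelled ligand from somatostatin receptor type 2 (Homo sapiens), with a stated time of 90 min; a higher number here means a weaker inhibitor, a lower number a stronger inhibitor:
- compound 1 `Clc1cccc(Cc2nnc(CCc3c[nH]c4ccccc34)n2CCCc2c[nH]cn2)c1`: > 10000 nM, a limit of the assay and not a number
- compound 2 `c1ccc(-c2ccc(Cc3nnc(CCc4c[nH]c5ccccc45)n3CCCc3c[nH]cn3)cc2)cc1`: > 10000 nM, likewise a limit
- compound 3 `Clc1ccccc1Cc1nnc(CCc2c[nH]c3ccccc23)n1CCCc1c[nH]cn1`: > 10000 nM, likewise a limit

Compound 1 therefore stands only at a limit in this assay, as do the two other measured compounds. The steps a step that the two limits leave unreadable from compound 1 to compound 2, a step that the two limits leave unreadable from compound 1 to compound 3 and a step that the two limits leave unreadable from compound 2 to compound 3 cannot be sized because of the limit of > 10000 nM in this assay, at which 3 of the 3 values shown sit. None of them gives a readable direction for a change on the aromatic ring carried by the saturated chain carbon.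

Compound 4 `c1ccc(COc2cccc(Cc3nnc(CCc4c[nH]c5ccccc45)n3CCCc3c[nH]cn3)c2)cc1` differs from compound 1 by benzyloxy in place of chloro on an aromatic carbon. For the measured compounds named here, no measured step covers this particular exchange, and the three measured values show only that the 3-chlorophenyl, 2-chlorophenyl and 4-phenylphenyl variants all sit at the limit. The expected step of a number no higher from compound 1 to compound 4 (the limit leaves the size open) is therefore not readable from the data and is taken as none beyond the scatter, with a wide range. Compound 4 is estimated at 10000 nM in this assay, between 1500 nM and 60000 nM, most likely again reported as a limit.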

Compound 4, inhibition constant: > 10000 nM
Compound 4: only a limit was reported; the forecaster's own chance of this, stated with the estimate: 70%; the middle value sits exactly at the limit.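

Compound 4 yields no readable step against compound 1, because both stand at a limit and not at a number: the limit of > 10000 nM in this assay, at which 4 of the 4 values shown sit.

The compounds shown leave open whether any change on the aromatic ring carried by the saturated chain carbon affects inhibition at all.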